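The source may report more compounds than this note shows. Statements on the series, on what has been measured and on what is new or still open speak of the compounds shown alone.

Measured in a functional assay on cells (Neutrophil, Homo sapiens) for inhibition, with a stated time of 10 min; on this read-out higher numbers stand for weaker inhibition and lower numbers for stronger inhibition:

- Compound 1 `O=C(Nc1ccccc1)N1c2ccnn2CC1c1ccccc1` gives > 1000 nM, a limit
- Compound 2 `O=C(Nc1ccccc1F)N1c2ccnn2CC1c1ccccc1` gives > 1000 nM, a limit
- Compound 3 `O=C(Nc1cccc(F)c1)N1c2ccnn2CC1c1ccccc1` gives > 1000 nM, a limit

Compound 3 has no exact number, only the limit > 1000 nM. The same holds across the set, which shares (the limit of > 1000 nM in this assay, at which 3 of the 3 values shown sit). Compound 4 `O=C(NC1CC1)c1cnn2c1N(C(=O)Nc1cccc(F)c1)C(c1ccccc1)C2` carries cyclopropylcarbamoyl in place of hydrogen on an aromatic carbon, counted as cyclopropylcarbamoyl in place of hydrogen on an aromatic carbon. The measured steps closest to this, a step that the two limits leave unreadable from compound 1 to compound 3 and a step that the two limits leave unreadable from compound 2 to compound 3, concern only the fluoro and have no readable size. None of them tests the new group, so the expectation is loose: some move toward stronger inhibition, with a real chance of staying at the limit. The expected change is an at least 2.5-fold lower number from compound 3 to compound 4 (0.39 log units; beyond the scatter). Compound 4 is estimated at 400 nM, with an expected range from 20 nM to 5000 nM.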

Compound 4, half-maximal inhibitory concentration: > 1000 nM
Compound 4: only a limit was reported; the forecaster's own chance of this, stated with the estimate: 40%; middle value at least 2.5-fold (0.39 log units) from the limit.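

Going by these compounds alone, compound 3 and compound 4 both sit at a limit, so no step between them can be read: the limit of > 1000 nM in this assay, at which 4 of the 4 values shown sit. The compounds shown leave open how strongly each inhibits and whether cyclopropylcarbamoyl changes inhibition at all.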